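This account rests on a few compounds, and the source may have more. Where it says the series, first, only, none or still open, it means among the compounds named here.

Compound 1 `CNC(=O)c1cc(Oc2ccc(NC(=O)c3nccc(-c4ccccc4)n3)cc2)ccn1` gives 7310 nM in a functional assay on PC-3 cells (Homo sapiens) for cytotoxicity, read by MTT assay, with a stated time of 72 h; on this read-out higher numbers stand for weaker inhibition and lower numbers for stronger inhibition. Compound 2 `CNC(=O)c1cc(Oc2ccc(NC(=O)c3nccc(-c4ccc([N+](=O)[O-])cc4)n3)cc2)ccn1` reads > 100000 nM in this assay, and this is a limit of the assay, not a number. Compound 2 can therefore be placed only as far as that limit allows, and it has no exact position on the scale.

Among the compounds with values here, the only measured step, an at least 13-fold higher number from compound 1 to compound 2 (1.13 log units; beyond the scatter), came with nitro in place of hydrogen on an aromatic carbon. It was large and beyond the scatter.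

Compound 3 `CNC(=O)c1cc(Oc2ccc(NC(=O)c3nccc(-c4cccc(Cl)c4)n3)cc2)ccn1` has 3-chlorophenyl in place of 4-nitrophenyl on an aromatic carbon. The nitro group is gone again, so the step from compound 1, with its 7310 nM, to compound 2 bears directly on this change and suggests a large move to a lower number in this assay. Within the data shown here, no measured step covers the chlorine, so the expected landing place near compound 1 remains uncertain.

The expected change is an at least 12-fold lower number from compound 2 to compound 3 (1.09 log units; beyond the scatter).

For compound 3 the estimated value is 8000 nM, with an expected range from 2000 nM to 35000 nM.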

Compound 3, half-maximal inhibitory concentration: 20800 nM
For compound 3 the middle estimate is 2.6-fold (0.41 log units) below the measured one; low and high end bracket the measured number.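

In this assay, 3-chlorophenyl in place of 4-nitrophenyl, on an aromatic carbon of the six-membered aromatic ring with 2 nitrogen, brings the read-out back to a measurable number, with an at least 4.8-fold lower number from compound 2 to compound 3 (0.68 log units; beyond the scatter). The chlorine does not restore the level of the plain phenyl, however: chloro in place of hydrogen goes with a 2.8-fold higher number from compound 1 to compound 3 (0.45 log units; beyond the scatter), so both substituted phenyl groups shown at this position read higher than the plain phenyl, by steps beyond the scatter, and neither lowers the number. The step from the nitro compound gives only a minimum size, since compound 2 stands at a limit and not at a number: the limit of > 100000 nM in this assay, at which 1 of the 3 values shown sits.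

Whether the rise with chlorine belongs to the chlorine itself or to the place it holds on the phenyl stays open, since the compounds shown offer a single chlorinated example. Equally open, going by these compounds, is whether a methoxy group or an amine on this phenyl would leave the number where it stands for the plain phenyl, raise it further, or bring it lower.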